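mGlu5 negative modulator series: oxadiazolyl azetidine amides and ureas

This account rests on a few compounds, and the source may have more. Where it says the series, first, only, none or still open, it means among the compounds named here.

Measured so far:
- compound 1 `O=C(C1CCCO1)N1CC(c2nc(-c3cccc(Cl)c3)no2)C1`: 890 nM
- compound 2 `Cc1cccc(-c2noc(C3CN(S(=O)(=O)c4ccc(Cl)cc4)C3)n2)c1`: 1100 nM

Two compounds have numbers in an assay on HEK293 cells for negative allosteric modulation of metabotropic glutamate receptor 5 (Homo sapiens), read by FLIPR; on this read-out lower numbers stand for stronger inhibition and higher numbers for weaker inhibition. Compound 1 gives 890 nM and compound 2 gives 1100 nM; compound 1 has the lower number of the two, but the gap to compound 2 lies within the scatter, so the pair shows no difference in activity.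

Compound 3 `COC1CCN(C(=O)N2CC(c3nc(-c4cccc(Cl)c4)no3)C2)CC1` is not yet measured. It keeps the core of compound 1 and changes one place: 4-methoxypiperidin-1-yl in place of oxolan-2-yl on a carbonyl carbon. The change replaces an oxolan-2-yl on a carbonyl carbon with a 4-methoxypiperidin-1-yl, so the acyl group of compound 1 becomes a urea-type group in compound 3.

For the measured compounds named here, no step between measured compounds covers a change of this kind, so the direction cannot be read from the series. The two numbers in this assay sit close together despite a large change in the group on the azetidine nitrogen, which argues for a modest step. Compound 3 is expected at 600 nM, with a range from 150 nM to 2500 nM; the expected step of a 1.5-fold lower number from compound 1 to compound 3 (0.17 log units; within the scatter) is small and may not exceed the scatter.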

Compound 3, half-maximal inhibitory concentration: > 10000 nM
Compound 3 gave a limit, no number; the forecaster's own chance of this, stated with the estimate: 10%; middle value at least 16-fold (1.22 log units) away from the limit.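

In this assay, for the compounds shown here, exchanging oxolan-2-yl for 4-methoxypiperidin-1-yl on a carbonyl carbon gives an at least 11-fold higher number from compound 1 to compound 3 (1.05 log units; beyond the scatter), the first step that isolates this position, and it shows that activity here depends strongly on the group carried. Compound 3 gives > 10000 nM, which is a limit of the assay and not a number. The step is therefore a minimum, and its full size cannot be read from this pair: the limit of > 10000 nM in this assay, at which 1 of the 3 values shown sits.

The single change turns the acyl group of compound 1 into a urea-type group and also replaces a five-membered ring with a six-membered ring bearing a methoxy group, and the compounds shown do not separate these features. Still open, on these data alone, is whether a urea with an unsubstituted piperidin-1-yl or a morpholin-4-yl group would keep activity, and whether an amide with 4-methoxycyclohexyl or oxan-4-yl on the carbonyl carbon would follow compound 1 or compound 3.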